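Adding a second fluorine to the phenyl ring of a urea antagonist

The source may hold more compounds than are shown below. What is called first, only, known or untested is meant among the compounds shown, and "the series" means these compounds.

Measured compounds:
- compound 1 `Cn1ncc2cc(NC(=O)NCc3cc(C(F)(F)F)nn3-c3cccc(Cl)c3)ccc21`: 61 nM
- compound 2 `Cn1ncc2c(NC(=O)NCc3cc(C(F)(F)F)nn3-c3cccc(C(F)(F)F)c3)cccc21`: 1.4 nM
- compound 3 `Cn1ncc2c(NC(=O)NCc3cc(C(F)(F)F)nn3-c3ccc(F)cc3)cccc21`: 8.4 nM

In an assay on CHO-K1 cells for antagonist activity at transient receptor potential cation channel subfamily V member 1 (Homo sapiens), read by FLIPR and calcium flux, with a stated time of 6 min (a higher number here means a weaker inhibitor, a lower number a stronger inhibitor), compound 3 gives 8.4 nM, which places it second highest of the three numbers. Its nearest neighbour is compound 2, whose value in this assay is 1.4 nM; compound 1 stands furthest away with 61 nM.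

Compound 4 `Cn1ncc2c(NC(=O)NCc3cc(C(F)(F)F)nn3-c3ccc(F)c(F)c3)cccc21` has not yet been measured. It differs from compound 3 by fluoro in place of hydrogen on an aromatic carbon.

Among the measured compounds shown here, the only step that bears on this change is a 6.0-fold higher number from compound 2 to compound 3 (0.78 log units; beyond the scatter), which shows that a substituted phenyl carrying a group at that ring position held a lower number than the plain 4-fluorophenyl. A single fluorine is far smaller than trifluoromethyl, so a smaller effect, if any, would be expected. Compound 1 carries a different core attachment and does not give a clean comparison.

For compound 4 the expected outcome in this assay is therefore a step of a 1.7-fold lower number from compound 3 to compound 4 (0.23 log units; within the scatter), toward a somewhat lower number, and compound 4 is estimated at 5 nM, ranging from 1.5 nM to 15 nM.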

Compound 4, inhibition constant: 4.9 nM
Estimate against measurement, compound 4: 1.0-fold (0.01 log units) above; the measured number falls inside the stated range.
By their numbers in this assay, from the lowest: compound 2; then compounds 4 and 3 (each within the scatter of the next); then compound 1.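

In this assay, a second fluoro group on the ring, turning 4-fluorophenyl into 3,4-difluorophenyl, gives a 1.7-fold lower number from compound 3 to compound 4 (0.23 log units; within the scatter) and so stays within the usual scatter, which means this position accepts the extra fluorine without a change that can be told apart from assay noise. The 3-(trifluoromethyl)phenyl ring remains distinct, with 3,4-difluorophenyl in its place giving a 3.5-fold higher number from compound 2 to compound 4 (0.54 log units; beyond the scatter) and thus a gap beyond the scatter. Nothing measured here explains either step.

On these data alone, it remains open how a 3-fluorophenyl ring, without the fluoro group of compound 4 that is already present in compound 3, would compare with compound 2. Also open, as far as these compounds go, is how a larger or different group at this position, such as methoxy or an amine, would read out in this assay on this shared core.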